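A few compounds are considered here, and "the series" means these few. Any claim that something is new, unique, unknown or untested is made for them only; others in the source may bear on it.

The study takes three compounds built on one shared core and tests them in a functional assay on MCF7 cells (Homo sapiens) for antiproliferative activity, read by MTT assay, with a stated time of 48 h; on this read-out higher numbers stand for weaker inhibition and lower numbers for stronger inhibition. Compound 1 `N#CC1=C(N)Oc2c(c3nc4ccccc4nc3c3ccccc23)C12C(=O)N(Cc1cnnn1-c1ccc([N+](=O)[O-])cc1)c1ccccc12` carries a 4-nitrophenyl group. In this assay compound 1 gives > 50000 nM, which is a limit of the assay and not a number. Compound 2 `CC(=O)Nc1ccc(-n2nncc2CN2C(=O)C3(C(C#N)=C(N)Oc4c3c3nc5ccccc5nc3c3ccccc43)c3ccccc32)cc1` has acetamido in place of nitro on an aromatic carbon. In this assay compound 2 gives > 50000 nM, again only a limit. Compound 3 `Cc1ccc(-n2nncc2CN2C(=O)C3(C(C#N)=C(N)Oc4c3c3nc5ccccc5nc3c3ccccc43)c3ccccc32)cc1C` bears 3,4-dimethylphenyl on an aromatic nitrogen. In this assay compound 3 gives > 50000 nM, a limit and not a number. Compound 3 thus stands where the other two stand, as the record shows (the limit of > 50000 nM in this assay, at which 3 of the 3 values shown sit). The measured steps are accordingly unreadable: a step that the two limits leave unreadable from compound 1 to compound 2, a step that the two limits leave unreadable from compound 1 to compound 3 and a step that the two limits leave unreadable from compound 2 to compound 3 are bounded on both sides by the same limit and show no size.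

Compound 4 `Cc1ccc(C)c(-n2nncc2CN2C(=O)C3(C(C#N)=C(N)Oc4c3c3nc5ccccc5nc3c3ccccc43)c3ccccc32)c1` differs from compound 3 in one place: 2,5-dimethylphenyl in place of 3,4-dimethylphenyl on an aromatic nitrogen, the two having the same atoms joined differently. The three measured steps bear on it only in that none of them revealed a readable change among these phenyl substituents, so nothing shows whether the swap of 3,4-dimethylphenyl for 2,5-dimethylphenyl matters. The author therefore expects no readable step, a step that the limit leaves unreadable from compound 3 to compound 4. She expects compound 4 to return 60000 nM in this assay, within 20000 nM to 200000 nM, most probably reported once more as a limit.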

Compound 4, half-maximal inhibitory concentration: > 50000 nM
Compound 4: a limit, no number; the forecaster's own chance of this, stated with the estimate: 85%; the middle value is on the limit's open side.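

In this assay compound 4 gives > 50000 nM, a limit and not a number. For the compounds shown here, no step from compound 1, compound 2 or compound 3 to compound 4 can be read, and all four compounds sit together: the limit of > 50000 nM in this assay, at which 4 of the 4 values shown sit. The compounds shown leave open whether these phenyl substituents differ in activity at all; none of them has a number.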